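Swapping the ring on the ring nitrogen of compound 3

The source may hold more compounds than are shown below. What is called first, only, known or untested is meant among the compounds shown, and "the series" means these compounds.

Measured compounds:
- compound 1 `COc1ccc(F)cc1N1C(=O)CSC1c1cccc(C(=O)NCCCCc2ccccc2)c1`: 1250 mL.min-1.g-1
- compound 2 `O=C(NCCCCn1cccn1)c1cccc(C2SCC(=O)N2c2ccccn2)c1`: 82.1 mL.min-1.g-1
- compound 3 `O=C(NCCCCc1ccccc1)c1cccc(C2SCC(=O)N2c2ccccn2)c1`: 412 mL.min-1.g-1

All three were run in an ADME assay on microsomes from liver (Homo sapiens) for metabolic stability, read by LC-MS, using NADPH, with a stated time of 10 min, tested at 0.1 uM; on this read-out higher numbers stand for fast clearance and lower numbers for slow clearance. Compound 3 stands second highest of the three numbers. Its nearest neighbour is compound 1, which gives 1250 mL.min-1.g-1 in this assay, and the step of a 3.0-fold lower number from compound 1 to compound 3 (0.48 log units; beyond the scatter) is a modest one, beyond the scatter. Further away is compound 2 with 82.1 mL.min-1.g-1, where the step of a 5.0-fold higher number from compound 2 to compound 3 (0.70 log units; beyond the scatter) is also modest and beyond the scatter.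

Compound 4 `O=C(NCCCCc1ccccc1)c1cccc(C2SCC(=O)N2c2cccc(F)c2)c1` has not yet been measured. Its difference from compound 3 is 3-fluorophenyl in place of pyridin-2-yl on an amide-type nitrogen in a ring. For the measured compounds named here, of the two measured steps, only the one from compound 1 to compound 3 touches the same position, the amide-type nitrogen in the ring; there, pyridin-2-yl in place of 5-fluoro-2-methoxyphenyl gave the lower number a 3.0-fold lower number from compound 1 to compound 3 (0.48 log units; beyond the scatter). Compound 4 moves back to a six-membered aromatic ring of carbon only, though a different one, so a rise of similar order is the natural guess, with the caveat that a single step is a thin basis. For compound 4 a step of a 2.1-fold higher number from compound 3 to compound 4 (0.31 log units; beyond the scatter) is expected. Compound 4 is therefore estimated at 850 mL.min-1.g-1, with a range from 400 mL.min-1.g-1 to 1800 mL.min-1.g-1.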

Compound 4, intrinsic clearance in microsomes: 1840 mL.min-1.g-1
Estimate against measurement, compound 4: 2.2-fold (0.34 log units) below, outside the stated range (above it).
By their numbers in this assay, from the lowest: compound 2; then compound 3; then compounds 1 and 4 (each within the scatter of the next).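

On the ring nitrogen, the step of a 4.5-fold higher number from compound 3 to compound 4 (0.65 log units; beyond the scatter) makes pyridin-2-yl the odd one out so far: compound 1 and compound 4, which both carry a carbon-only ring there, each give a clearly higher clearance number than compound 3. The step of a 1.5-fold higher number from compound 1 to compound 4 (0.17 log units; within the scatter) adds something new, since hydrogen in place of methoxy on an aromatic carbon leaves the read-out within the scatter, so the methoxy group of compound 1 does not account for the gap between that compound and compound 3. Nothing measured here says why the ring matters, and the change from compound 3 to compound 4 removes a ring nitrogen and adds a fluorine at once, so the two contributions cannot be told apart.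

As far as these compounds go, a plain phenyl ring on the same nitrogen would help to separate those two contributions, and how a pyridin-3-yl ring would compare remains open. Also open, from the compounds shown here alone, is whether 1H-pyrazol-1-yl on the chain, which goes with the lower number of compound 2 against compound 3, would bring the number down in the same way when paired with 3-fluorophenyl.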